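Decyl to 4-methoxyphenyl on the triazole bearing carbon

The source may hold more compounds than are shown below. What is called first, only, known or untested is meant among the compounds shown, and "the series" means these compounds.

Working notes on a small set of bis(benzyloxy) lactone triazoles. Compound 1 `O=C1O/C(=C\Cn2cc(-c3ccc(Br)cc3)nn2)C(OCc2ccccc2)=C1OCc1ccccc1` gives 24300 nM in a functional assay on HeLa cells (Homo sapiens) for antiproliferative activity, read by MTT assay, with a stated time of 72 h; a lower number here means a stronger inhibitor, a higher number a weaker inhibitor. Compound 3 `O=C1O/C(=C\Cn2cc(-c3cccc(O)c3)nn2)C(OCc2ccccc2)=C1OCc1ccccc1` gives 74800 nM in this assay. Compound 2 `CCCCCCCCCCc1cn(C[C@H](O)[C@H]2OC(=O)C(OCc3ccccc3)=C2OCc2ccccc2)nn1` gives 22900 nM in this assay, the low end of the three numbers, though its gap to compound 1 is within the scatter and only its gap to compound 3 is beyond it. Going by the values given here, the one step available, a 3.1-fold higher number from compound 1 to compound 3 (0.49 log units; beyond the scatter), concerns a change on the aryl group of the triazole.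

Compound 4 `COc1ccc(-c2cn(C[C@H](O)[C@H]3OC(=O)C(OCc4ccccc4)=C3OCc3ccccc3)nn2)cc1` is not yet measured. The change from compound 2 is 4-methoxyphenyl in place of decyl on an aromatic carbon. Among the compounds with values here, no measured pair swaps a chain for an aryl group at this position, so the step from compound 1 to compound 3 bears only indirectly: it shows that aryl variation at this carbon moves the number by a modest amount, and that the aryl-bearing compound 1 and the decyl-bearing compound 2 sit within the scatter of each other. On that basis a small step is expected, a 1.4-fold higher number from compound 2 to compound 4 (0.15 log units; within the scatter), in this assay, with a mild lean toward a higher number. The estimate for compound 4 is 32000 nM, with a range from 12000 nM to 85000 nM.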

Compound 4, half-maximal inhibitory concentration: 16400 nM
Compound 4: the middle estimate sits 2.0-fold (0.29 log units) above what was measured; measured number inside the range.
By their numbers in this assay, from the lowest: compounds 4, 2 and 1 (each within the scatter of the next); then compound 3.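

In this assay, going by these compounds alone, the step from the chain to the aryl group is the first direct comparison at this aromatic carbon on a single core, and it gives a 1.4-fold lower number from compound 2 to compound 4 (0.14 log units; within the scatter). Decyl leaves with its 10 heavy atoms and no ring, 4-methoxyphenyl enters with a six-membered aromatic ring and a hydrogen-bond acceptor, and yet the pair stays within the scatter, so on this core the assay does not separate the two groups. Nothing at hand offers a reason why two such different groups read alike here.

The compounds shown leave open how a chain compares with an aryl group on the core of compound 1, whose link to the triazole differs from that of compound 2 and compound 4, so the 3-hydroxyphenyl and 4-bromophenyl step cannot yet be carried over to this core. Also open, from the compounds shown here alone, is what an amine, a carboxylic acid or a chain longer than decyl would do on this aromatic carbon, and whether any group there gives a step beyond the scatter on the core of compound 2.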